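Aryl variation on the five-membered ring of the butenolide series

This account rests on a few compounds, and the source may have more. Where it says the series, first, only, none or still open, it means among the compounds named here.

Compound 1 `O=C1O[C@H]([C@@H](O)Cn2cc(-c3ccc(Br)cc3)nn2)C(OCc2ccccc2)=C1OCc1ccccc1` and compound 2 `O=C1O[C@H]([C@@H](O)Cn2cc(-c3cc(F)cc(F)c3)nn2)C(OCc2ccccc2)=C1OCc1ccccc1` share a core and differ only in the aryl group on the five-membered aromatic ring with 3 nitrogen. In a functional assay on A549 cells (Homo sapiens) for antiproliferative activity, read by MTT assay, with a stated time of 72 h (a lower number here means a stronger inhibitor, a higher number a weaker inhibitor), compound 1 gives 750 nM, and compound 2 gives 41200 nM. Among the measured compounds shown here, compound 2 thus stands at the higher of the two measured numbers, its nearest neighbour being compound 1, and the single measured step of a 55-fold higher number from compound 1 to compound 2 (1.74 log units; beyond the scatter) is large. Compound 3 `COc1ccc(-c2cn(C[C@H](O)[C@H]3OC(=O)C(OCc4ccccc4)=C3OCc3ccccc3)nn2)cc1` differs from compound 2 by 4-methoxyphenyl in place of 3,5-difluorophenyl on an aromatic carbon. For the measured compounds named here, the one step on record shows that the aryl group moves this assay strongly, but no measured pair covers 4-methoxyphenyl itself; the expectation therefore rests on compound 1, whose 4-bromophenyl gave 750 nM in this assay. The expected step in this assay is a 14-fold lower number from compound 2 to compound 3 (1.14 log units; beyond the scatter), downward, without a full return to the lower number. Compound 3 is accordingly estimated at 3000 nM, within 600 nM to 15000 nM.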

Compound 3, half-maximal inhibitory concentration: 28300 nM
Beside the measured number, compound 3's estimate is 9.4-fold (0.97 log units) below it; measured number outside the range, above it.
By their numbers in this assay, from the lowest: compound 1; then compounds 3 and 2 (each within the scatter of the next).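

The step of a 1.5-fold lower number from compound 2 to compound 3 (0.16 log units; within the scatter) in this assay shows that 4-methoxyphenyl and 3,5-difluorophenyl cannot be told apart at this position on the ring with 3 nitrogen, even though 4-methoxyphenyl carries a hydrogen-bond acceptor and 3,5-difluorophenyl carries none. The step of a 38-fold higher number from compound 1 to compound 3 (1.58 log units; beyond the scatter) is large and comes from methoxy in place of bromo alone, so the gap seen earlier does not depend on the 3,5-difluoro pattern, and among these three compounds only compound 1 stands apart. No measurement on hand explains why the bromo compound differs.

From the compounds shown here alone, it remains open whether the low number of compound 1 belongs to bromo alone or would also appear with chloro or iodo in its place. An unsubstituted phenyl would show whether the bromo compound or the other two are the exception.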